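The compounds below may be only part of what the source reports. "The series", "measured", "known", "first", "only" and "open" are said of these compounds alone.

Measured so far in an assay on isolated protein for inhibition of protein deacetylase HDAC6 (Homo sapiens), read by mobility shift assay; a lower number here means a stronger inhibitor, a higher number a weaker inhibitor:
compound 1 `O=C(NO)c1ccc(CN(Cc2ccccc2)S(=O)(=O)c2c(F)c(F)c(F)c(F)c2F)cc1`: 9 nM
compound 2 `CN(C)c1ccc(CN(Cc2ccc(C(=O)NO)cc2)S(=O)(=O)c2c(F)c(F)c(F)c(F)c2F)cc1`: 29 nM
compound 3 `Cc1ccc(CN(Cc2ccc(C(=O)NO)cc2)S(=O)(=O)c2c(F)c(F)c(F)c(F)c2F)cc1`: 6 nM

Compound 2 stands highest of the three numbers; the step of a 3.2-fold higher number from compound 1 to compound 2 (0.51 log units; beyond the scatter) and the step of a 4.8-fold lower number from compound 2 to compound 3 (0.68 log units; beyond the scatter) both lie beyond the scatter, while a 1.5-fold lower number from compound 1 to compound 3 (0.18 log units; within the scatter) does not. Compound 4 `O=C(NO)c1ccc(CN(Cc2ccncc2)S(=O)(=O)c2c(F)c(F)c(F)c(F)c2F)cc1` is not yet measured. The change from compound 2 is pyridin-4-yl in place of 4-(dimethylamino)phenyl on a saturated chain carbon bound to a sulfonamide nitrogen. Both steps that bear on it show that removing the dimethylamino lowers the number in this assay by a modest amount; nothing measured here speaks to the ring nitrogen entering. A modest step down is therefore expected, a 2.9-fold lower number from compound 2 to compound 4 (0.46 log units; beyond the scatter), bringing compound 4 back near compound 1 and compound 3. The estimate for compound 4 is 10 nM, with a range from 4 nM to 30 nM.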

Compound 4, half-maximal inhibitory concentration: 14 nM
The estimate for compound 4 lay 1.4-fold (0.15 log units) below the measured number, within the range that was stated.
By their numbers in this assay, from the lowest: compounds 3, 1 and 4 (each within the scatter of the next, the first and the last beyond it); then compound 2.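

In this assay, for the compounds shown here, pyridin-4-yl on a saturated chain carbon bound to a sulfonamide nitrogen is the first ring with a hetero atom at this place, and it stays level with phenyl (a 1.6-fold higher number from compound 1 to compound 4 (0.19 log units; within the scatter)). The same group separates from both substituted rings, in opposite directions (a 2.3-fold higher number from compound 3 to compound 4 (0.37 log units; beyond the scatter); a 2.1-fold lower number from compound 2 to compound 4 (0.32 log units; beyond the scatter)). Nothing available explains these steps.

Pyridin-3-yl and pyridin-2-yl remain open at this place, so the effect of where the ring nitrogen sits cannot be read. On these data alone, a 4-carboxyphenyl group is also open.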